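The compounds below may be only part of what the source reports. "The series", "measured", "known", "first", "only" and "open" are said of these compounds alone.

Measured compounds:
Compound 1, `Cc1ccc(C(=O)/C=C/c2ccc(C(=O)NCCCNc3ccnc4cc(Cl)ccc34)cc2)o1`: 74500 nM
Compound 3, `Cc1ccc(C(=O)/C=C/c2ccc(C(=O)NC(C)CNc3ccnc4cc(Cl)ccc34)cc2)o1`: 10000 nM
Compound 2, `Cc1ccc(C(=O)/C=C/c2ccc(C(N)=O)cc2)o1`: "not determined" (no result reported)

In an ADME assay on WI-38 cells (Homo sapiens) for cytotoxicity, read by sulforhodamine B assay, with a stated time of 48 h (a lower number here means a stronger inhibitor, a higher number a weaker inhibitor), compound 1 gives 74500 nM, while compound 3 gives 10000 nM. Both carry the shared core joined through an amide to a longer chain; compound 2 carries the same core but ends in a primary amide, and for compound 2 no result was reported in this assay, so compound 2 stands on no number at all. Compound 4, `Cc1ccc(C(=O)/C=C/c2ccc(C(=O)O)cc2)o1`, differs from compound 2 in one place: hydroxy in place of amino on a carbonyl carbon. For the measured compounds named here, since no pair of measured compounds shows this change, the size of the step cannot be read from the data. The author expects the step from compound 2 to compound 4 in this assay to be small, with no direction beyond the usual scatter, and expects a weak result in any case, as compounds 1 and 3 are already weak. Compound 4 is estimated at 100000 nM, with a range from 20000 nM to 400000 nM, and a limit rather than a number may well be reported.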

Compound 4, half-maximal inhibitory concentration: > 100000 nM
Compound 4: only a limit was reported; the forecaster's own chance of this, stated with the estimate: 45%; the middle value lies on the limit itself.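

In this assay compound 4 gives > 100000 nM, which is a limit and not a number. For the compounds shown here, compound 2 has no number to set against it, so no step between compound 2 and compound 4 can be read. The compounds shown leave open what hydroxy in place of amino on the carbonyl carbon does in this assay.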